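Lengthening the Chain of Compound 3

The compounds below may be only part of what the source reports. "The series", "measured", "known", "first", "only" and "open" are said of these compounds alone.

In an ADME assay on Vero cells (Chlorocebus sabaeus) for cytotoxicity, read by reporter gene assay, with a stated time of 4 days (a lower number here means a stronger inhibitor, a higher number a weaker inhibitor), compound 3 `CCCCCCCC(=O)OCC(C)(C)CC1=C(O)C(=O)c2ccccc2C1=O` gives no number, only a limit: > 258000 nM. Compound 4 `CCCCCCCCCCCCCCCC(=O)OCC(C)(C)CC1=C(O)C(=O)c2ccccc2C1=O` is still unmeasured and differs by one change: octyl in place of hydrogen on a saturated chain carbon, seven bonds along the chain from a carbonyl carbon. Going by the values given here, one measured step bears on this. Compound 1 `CCCCCCCCC(=O)NCC(C)(C)CC1=C(O)C(=O)c2ccccc2C1=O` gives 16700 nM, and compound 2 `CCCCCCCCCCC(=O)NCC(C)(C)CC1=C(O)C(=O)c2ccccc2C1=O` gives 14900 nM. That step, a 1.1-fold lower number from compound 1 to compound 2 (0.05 log units; within the scatter), lies within the scatter, but it adds only ethyl, so it is a thin guide to adding octyl. Given a 1.1-fold lower number from compound 1 to compound 2 (0.05 log units; within the scatter), no large step is expected from the longer chain, and compound 4 may also return only a limit. Any number that appears is expected to be somewhat lower, and the estimated step is an at least 2.1-fold lower number from compound 3 to compound 4 (0.33 log units; beyond the scatter). For compound 4 the estimate is 120000 nM, with an expected range of 30000 nM to 260000 nM.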

Compound 4, half-maximal inhibitory concentration: 4410 nM
Compound 4: the middle estimate sits 27-fold (1.43 log units) above what was measured; measured number below the stated range.
By their numbers in this assay, from the lowest: compound 4; then compounds 2 and 1 (each within the scatter of the next). At a limit, above all of these: compound 3.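

In this assay, this position on the chain is far from silent: octyl in place of hydrogen gives an at least 58-fold lower number from compound 3 to compound 4 (1.76 log units; beyond the scatter). The ethyl added to the amide chain gave only a 1.1-fold lower number from compound 1 to compound 2 (0.05 log units; within the scatter), so that small step did not foretell this large one, although the two steps sit on different chains. The full size of the new step stays unknown, as compound 3 carries only a limit: the limit of > 258000 nM in this assay, at which 1 of the 4 values shown sits.

Still open, on these data alone, is whether the number falls gradually or abruptly between these two chain lengths. A longer chain, or a carboxylic acid at the chain end, might also behave differently.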